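Methyl in place of nitro on the shared core

The source may hold more compounds than are shown below. What is called first, only, known or untested is meant among the compounds shown, and "the series" means these compounds.

In an ADME assay on Vero cells (Chlorocebus sabaeus) for cytotoxicity, read by neutral red uptake, tested at 25 ug/mL (on this read-out lower numbers stand for a stronger effect and higher numbers for a weaker effect at the one concentration tested), compound 3 `O=C1CSC(c2ccc([N+](=O)[O-])cc2)N1CCN1CCCCC1` gives 100%. Compound 1 `COc1ccc(C2SCC(=O)N2CCN2CCCCC2)cc1` gives 100% in this assay, and compound 2 `O=C1CSC(c2cccc(Cl)c2)N1CCN1CCCCC1` gives 100% there, so compound 3 stands level with both within the scatter. Going by the values given here, the only measured step between these compounds, no change at the digits printed from compound 1 to compound 3 (within the scatter), is an exchange on the same aromatic carbon as the one now considered. Compound 4 `Cc1ccc(C2SCC(=O)N2CCN2CCCCC2)cc1` differs from compound 3 by methyl in place of nitro on an aromatic carbon. Because no change at the digits printed from compound 1 to compound 3 (within the scatter) stayed within the scatter, the step of no change at the digits printed from compound 3 to compound 4 (within the scatter) is expected to stay within it as well, with no direction favoured. Compound 4 is therefore estimated at 100% in this assay, with a range from 90% to 100%.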

Compound 4, a percentage reported as activity, at one concentration (the size of the read-out at that concentration, not a potency): 100%
Compound 4: middle estimate and measured number agree at the digits printed, and the stated range covers the measured number.
By their numbers in this assay, from the lowest: compounds 1, 2, 3 and 4 (each within the scatter of the next).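

In this assay the read-out shows no change at the digits printed from compound 3 to compound 4 (within the scatter) and no change at the digits printed from compound 1 to compound 4 (within the scatter), so methyl, which carries no hydrogen-bond acceptor, reads level with nitro and methoxy on this aromatic carbon. The exchange of the whole aryl group also shows no change at the digits printed from compound 2 to compound 4 (within the scatter). No evidence is available to explain these level readings. From the compounds shown here alone, whether an amine or a carboxylic acid on this aromatic carbon would also read level stays open. So does whether any group here would differ at another concentration, since all four compounds were read at one concentration only.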